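The source may hold more compounds than are shown below. What is called first, only, known or untested is meant among the compounds shown, and "the series" means these compounds.

Compound 1, `ClCc1ccc(Cn2cnc3c(Cl)ncnc32)cc1`, has no number in a functional assay on SNB-75 cells (Homo sapiens) for cytotoxicity, read by sulforhodamine B assay, with a stated time of 48 h; a higher number here means that more compound is tolerated, a lower number that less compound is tolerated; its result was reported as "not determined" (no result reported), so it gives no foothold of its own. Two related compounds do carry values. Compound 2, `ClCc1cccc(Cn2cnc3ncnc(Cl)c32)c1`, gives 7940 nM in this assay. Compound 3, `ClCc1ccc(Cn2cnc3nc(Cl)nc(Cl)c32)cc1`, gives 7410 nM in this assay, and the two readings sit close together. Compound 4, `ClCc1ccc(Cn2cnc3c(Cl)nc(Cl)nc32)cc1`, is the target of the step from compound 1: chloro in place of hydrogen on an aromatic carbon. Within the data shown here, no measured pair shows what this change does to the readout, so the step from compound 1 to compound 4 cannot be sized from data; with the neighbouring values of compound 2 and compound 3 both in the same region, a result in that region, with no shift beyond the scatter, is what one would expect. Compound 4 is therefore estimated at 7500 nM in this assay, with a range from 3000 nM to 20000 nM.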

Compound 4, concentration lethal to 50% of the cells: 45700 nM
Compound 4: middle estimate off by 6.1-fold (0.78 log units), on the low side; measured number above the stated range.
By their numbers in this assay, from the lowest: compounds 3 and 2 (each within the scatter of the next); then compound 4.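

Compound 1 has no number to set against compound 4, so no step can be read from this result, and no evidence on hand bears on it. In this assay, as far as these compounds go, the effect of chloro in place of hydrogen remains open.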